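A Second Chloro on the Phenyl Ring

A few compounds are considered here, and "the series" means these few. Any claim that something is new, unique, unknown or untested is made for them only; others in the source may bear on it.

Compound 1 `CN1CCN([C@@H]2CN[C@H](C(=O)N3CCSC3)C2)CC1`: 81.1 nM in an assay on a cell-free system (plasma) for inhibition of Dipeptidyl peptidase 4 (Rattus norvegicus), read by fluorescence; on this read-out lower numbers stand for stronger inhibition and higher numbers for weaker inhibition
Compound 2 `COc1ccc(N2CCN([C@@H]3CN[C@H](C(=O)N4CCSC4)C3)CC2)cc1`: 16.9 nM
Compound 3 `O=C([C@@H]1C[C@H](N2CCN(c3cccc(Cl)c3)CC2)CN1)N1CCSC1`: 7.2 nM

Compound 3 holds the lowest number of the three measured compounds, and both of its distances from the others lie beyond the scatter. The three measured steps are a 4.8-fold lower number from compound 1 to compound 2 (0.68 log units; beyond the scatter), an 11-fold lower number from compound 1 to compound 3 (1.05 log units; beyond the scatter) and a 2.3-fold lower number from compound 2 to compound 3 (0.37 log units; beyond the scatter). Each of them exchanges the whole group on the amine nitrogen in the ring, so each tells something about how that part of the molecule weighs on this assay.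

Compound 4 `O=C([C@@H]1C[C@H](N2CCN(c3ccc(Cl)c(Cl)c3)CC2)CN1)N1CCSC1` is the next step. Compared with compound 3 the change is chloro in place of hydrogen on an aromatic carbon. Going by the values given here, no measured step adds a single atom to an aryl group that is already in place, so the bearing of the earlier steps is indirect: the two steps that introduced the 3-chlorophenyl group, from compound 1 and from compound 2, both lowered the number, and a second chloro keeps that group and extends it. A further lowering is plausible but not established, and a step that stays within the scatter is at least as likely. The estimate for compound 4 is therefore a small step, a 1.3-fold lower number from compound 3 to compound 4 (0.12 log units; within the scatter), giving an expected value of 5.5 nM with a range from 2 nM to 15 nM.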

Compound 4, half-maximal inhibitory concentration: 4.2 nM
The estimate for compound 4 lay 1.3-fold (0.12 log units) above the measured number; measured number inside the range.
By their numbers in this assay, from the lowest: compounds 4 and 3 (each within the scatter of the next); then compound 2; then compound 1.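

In this assay, a chloro on the aromatic carbon ortho to a chloro group and para to a large group gives a 1.7-fold lower number from compound 3 to compound 4 (0.23 log units; within the scatter), a step that stays within the scatter, so this single added atom cannot be told apart from no change at all. The shared core thus tolerates a second chloro on this phenyl ring without a loss that the assay can detect, which the earlier exchanges of the whole group could not show. The 3,4-dichlorophenyl group also stands clearly apart from the other two groups on the ring nitrogen, with a 4.0-fold lower number from compound 2 to compound 4 (0.60 log units; beyond the scatter) and a 19-fold lower number from compound 1 to compound 4 (1.29 log units; beyond the scatter) both beyond the scatter, but no measurement shown here accounts for these differences.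

The compounds shown leave open how a 4-chlorophenyl group, with a chloro on this carbon and none on the other, would compare with compound 3 and compound 4. Going by these compounds, it also remains unknown whether a trifluoromethyl, a nitrile or an amine on the same carbon would produce a step beyond the scatter.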